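Changing the phenyl group on the shared core

The source may hold more compounds than are shown below. What is called first, only, known or untested is meant among the compounds shown, and "the series" means these compounds.

In a functional assay on OVCAR-3 cells (Homo sapiens) for antiproliferative activity, read by spectrophotometry, with a stated time of 2 days (on this read-out lower numbers stand for stronger inhibition of growth and higher numbers for weaker inhibition of growth), compound 3 (`Cc1cc(C)cc(Nc2ncc(C(F)(F)F)c(N3Cc4cccc(N(C)S(C)(=O)=O)c4C3)n2)c1`) gives > 30000 nM as a limit of the assay and not a number. Compound 1 (`COc1cc(Nc2ncc(C(F)(F)F)c(N3Cc4cccc(N(C)S(C)(=O)=O)c4C3)n2)c(OC)cc1Cl`) gives > 30000 nM and that too is a limit. Compound 2 (`COc1cc(Nc2ncc(C(F)(F)F)c(N3Cc4cccc(N(C)S(C)(=O)=O)c4C3)n2)cc(OC)c1`) gives a true number of 630 nM on the same read-out. Compound 3 therefore stands at the limit of > 30000 nM in this assay, at which 2 of the 3 values shown sit, and has no exact place on the scale.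

Compound 4 (`CN(c1cccc2c1CN(c1nc(Nc3cc(Cl)cc(C(F)(F)F)c3)ncc1C(F)(F)F)C2)S(C)(=O)=O`) carries 3-chloro-5-(trifluoromethyl)phenyl in place of 3,5-dimethylphenyl on a nitrogen on an aromatic ring and keeps the rest of compound 3.

Two measured steps at this same place bear on the change. They are an at least 47-fold lower number from compound 1 to compound 2 (1.67 log units; beyond the scatter) and an at least 47-fold higher number from compound 2 to compound 3 (1.67 log units; beyond the scatter) and both are large, so a swap here has moved the result a long way. Neither step brings in chlorine or trifluoromethyl, and only compound 2 at 630 nM gives a number, so a number for compound 4 is not assured. A modest move towards stronger inhibition of growth is expected, estimated as an at least 2.5-fold lower number from compound 3 to compound 4 (0.39 log units; beyond the scatter) in this assay and no larger. For compound 4 the estimated concentration is 12000 nM within an expected range of 2000 nM to 30000 nM on these grounds.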

Compound 4, concentration for 50% growth inhibition: 21500 nM
Compound 4: middle estimate off by 1.8-fold (0.25 log units), on the low side; the range from low to high includes it.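

In this assay, the 3-chloro-5-(trifluoromethyl)phenyl group gives this position a second true number, so the 3,5-dimethoxyphenyl group of compound 2 no longer stands alone on the scale, and the change between these two groups now reads as a 34-fold higher number from compound 2 to compound 4 (1.53 log units; beyond the scatter). Against the two compounds held at a limit, the data give only floors, an at least 1.3-fold lower number from compound 3 to compound 4 (0.14 log units; that floor lies within the scatter) and an at least 1.3-fold lower number from compound 1 to compound 4 (0.14 log units; that floor lies within the scatter), so neither step is shown to go beyond the scatter. Compound 2 therefore remains the strongest of the four in this assay, while compound 1 and compound 3 stay at a limit and not at a number: the limit of > 30000 nM in this assay, at which 2 of the 4 values shown sit.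

On these data alone, how much of the result of compound 4 belongs to the chlorine and how much to the trifluoromethyl stays open, as does whether compound 2 needs both of its methoxy groups to reach its value. Also open, as far as these compounds go, is what a phenyl group carrying an amine or a carboxylic acid would do on this nitrogen.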